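Moving the methyl around the phenyl ring of compound 2

A few compounds are considered here, and "the series" means these few. Any claim that something is new, unique, unknown or untested is made for them only; others in the source may bear on it.

Measured so far:
compound 1 `O=C1CCc2cccc(Nc3ncc(-c4ccc(C(F)(F)F)cc4)o3)c2C1` 374 nM
compound 2 `Cc1ccccc1-c1cnc(Nc2cccc3c2CC(O)CC3)o1` 416 nM

In an in vitro functional assay on cells for antagonist activity at transient receptor potential cation channel subfamily V member 1 (Homo sapiens), read by FLIPR and calcium flux (a lower number here means a stronger inhibitor, a higher number a weaker inhibitor), compound 1 gives 374 nM and compound 2 gives 416 nM; compound 2 holds the higher of the two numbers, but the gap lies within the scatter, so neither can be called the stronger. Compound 3 `Cc1ccc(-c2cnc(Nc3cccc4c3CC(O)CC4)o2)cc1` is not yet measured. It keeps the core of compound 2 and differs by 4-methylphenyl in place of 2-methylphenyl on an aromatic carbon. Within the data shown here, no measured pair shows this change, so compound 3 is expected to sit near compound 2, with a step of a 1.5-fold lower number from compound 2 to compound 3 (0.17 log units; within the scatter) in the direction of a modestly lower number. Compound 3 is estimated at 280 nM, between 90 nM and 900 nM.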

Compound 3, half-maximal inhibitory concentration: 62 nM
For compound 3 the middle estimate is 4.5-fold (0.65 log units) above the measured one; the measured number lies below the stated range.
By their numbers in this assay, from the lowest: compound 3; then compounds 1 and 2 (each within the scatter of the next).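

In this assay, 4-methylphenyl in place of 2-methylphenyl gives a 6.7-fold lower number from compound 2 to compound 3 (0.83 log units; beyond the scatter) with no change in atoms, so the aryl group on this carbon of the five-membered ring responds to where its methyl sits alone. The earlier compounds shown here offered no single-place comparison and could not show this. Nothing at hand accounts for the step. Still open, from the compounds shown here alone, is whether a methoxy group or a chlorine in place of the methyl of compound 3 would keep this number. Compound 1 differs from compound 3 in more than one place, so neither of its differences can be read separately.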